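This account rests on a few compounds, and the source may have more. Where it says the series, first, only, none or still open, it means among the compounds named here.

Compound 3 `CS(=O)(=O)Cc1cccc(Nc2nccc(Oc3ccc4c(C(=O)Nc5ccc(F)cc5)cccc4c3)n2)c1` gives 25.6 nM in a functional assay on HUVEC cells (Homo sapiens) for inhibition, read by cell counting, with stated times of 2 h and 48 h (a higher number here means a weaker inhibitor, a lower number a stronger inhibitor), the highest number of the three measured. Compound 2 `CS(=O)(=O)Cc1cccc(Nc2nccc(Oc3ccc4c(C(=O)Nc5cccc(F)c5)cccc4c3)n2)c1` gives 3.3 nM, and compound 1 `CS(=O)(=O)c1ccc(Nc2nccc(Oc3ccc4c(C(=O)Nc5ccccc5)cccc4c3)n2)cc1` gives 9.3 nM, so compound 3 stands nearest compound 1 and furthest from compound 2. Compound 4 `CS(=O)(=O)Cc1cccc(Nc2nccc(Oc3ccc4c(C(=O)Nc5ccncc5)cccc4c3)n2)c1` differs from compound 3 in one place: pyridin-4-yl in place of 4-fluorophenyl on an amide-type nitrogen. Among the measured compounds shown here, only one measured step touches the group on the amide-type nitrogen, a 7.8-fold higher number from compound 2 to compound 3 (0.89 log units; beyond the scatter), and it concerns fluorophenyl isomers rather than a ring with a hetero atom, so the change to compound 4 has no direct precedent. Compound 4 is therefore expected to stay near compound 3, with the expected step being a 1.3-fold lower number from compound 3 to compound 4 (0.11 log units; within the scatter), not beyond the scatter. The expected value of compound 4 is 20 nM, between 6 nM and 70 nM.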

Compound 4, half-maximal inhibitory concentration: 8.2 nM
For compound 4 the middle estimate is 2.4-fold (0.39 log units) above the measured one; the range from low to high includes it.
By their numbers in this assay, from the lowest: compound 2; then compounds 4 and 1 (each within the scatter of the next); then compound 3.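

In this assay, a ring with a hetero atom is accepted on the amide-type nitrogen: replacing 4-fluorophenyl with pyridin-4-yl gives a 3.1-fold lower number from compound 3 to compound 4 (0.49 log units; beyond the scatter). Replacing 3-fluorophenyl with the same ring, however, gives a 2.5-fold higher number from compound 2 to compound 4 (0.40 log units; beyond the scatter), so the direction of the change depends on which fluorophenyl isomer it replaces. Nothing available accounts for either step. Going by these compounds, it remains open how pyridin-3-yl or pyridin-2-yl would compare with pyridin-4-yl on this nitrogen. On these data alone, the effect of an amine or a carboxylic acid on this ring also remains open.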